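This account rests on a few compounds, and the source may have more. Where it says the series, first, only, none or still open, it means among the compounds named here.

Compounds measured: compound 1 `NC(CCSCCNCC(=O)O)C(=O)O`, "not determined" (no result reported); compound 2 `CC(C)(CCSCCC(N)C(=O)O)CC(=O)O`, 84 nM; compound 3 `C[C@H](NCCSCCC(N)C(=O)O)C(=O)O`, "not determined" (no result reported).

Within the data shown here, in an assay for inhibition of betaine--homocysteine S-methyltransferase 1 (Homo sapiens) (a higher number here means a weaker inhibitor, a lower number a stronger inhibitor), compound 2 gives 84 nM, and this is the only number in the set, since compound 1 and compound 3 carry no reported result. Compound 4 `CC(C)(CCSCC[C@@H](N)C(=O)O)CC(=O)O` differs from compound 2 only in the drawing of one stereocentre: the two compounds have the same atoms and bonds; at least one stereo element is drawn with a configuration in one of them and without one in the other: 1 of 1 stereo elements differ; a stereocentre at a saturated chain carbon is drawn without a configuration in compound 2 and R in compound 4. Compound 2 thus stands for a mixture of both configurations, compound 4 for a single one. Among the measured compounds shown here, no step between two measured compounds exists here to guide the size of this change. If the drawn configuration carries the activity, a modest gain is expected; if not, a loss. The estimate for compound 4 is 60 nM (range 20 nM to 400 nM), an expected step of a 1.4-fold lower number from compound 2 to compound 4 (0.15 log units; within the scatter).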

Compound 4, half-maximal inhibitory concentration: 701 nM
Estimate against measurement, compound 4: 12-fold (1.07 log units) below; measured number above the stated range.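

Fixing this saturated chain carbon as R gives an 8.3-fold higher number from compound 2 to compound 4 (0.92 log units; beyond the scatter) in this assay so the drawn configuration here matters, and the single R form is a weaker inhibitor than the mixture. This suggests that the R form does not carry most of the activity of compound 2. The step can be tied to one difference alone: the fact that one of compounds 2 and 4 is drawn with a defined configuration and the other without, at the place where they differ.

Going by these compounds, whether the S configuration at this carbon gives a lower number than compound 2 stays open. So does how a phosphonic acid in place of either carboxylic acid would read in this assay.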